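Removing a methyl from an inactive indole-fused imide core

The source may hold more compounds than are shown below. What is called first, only, known or untested is meant among the compounds shown, and "the series" means these compounds.

Measured compounds:
- compound 1 `Cc1ccc2[nH]c3c4cn[nH]c4c4c(c3c2c1)C(=O)NC4=O` — > 100000 nM in a functional assay on U-373MG ATCC cells (Homo sapiens) for cytotoxicity, read by MTT assay, with a stated time of 72 h; a lower number here means a stronger inhibitor, a higher number a weaker inhibitor
- compound 2 `COc1ccc2[nH]c(-n3cccn3)cc2c1` — > 100000 nM

Both values above are limits of the assay rather than measured numbers. Compound 1 reaches only the limit > 100000 nM in this assay, so its true potency lies somewhere beyond the range that was tested. Compound 2, a smaller molecule with a different core, also gives only the limit > 100000 nM. Going by the values given here, every value shown therefore sits at the limit of > 100000 nM in this assay, at which 2 of the 2 values shown sit, and no measured step between two compounds exists to show how a structural change shifts potency here.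

Compound 3 `O=C1NC(=O)c2c1c1[nH]ncc1c1[nH]c3ccccc3c21` is not yet measured. It differs from compound 1 by hydrogen in place of methyl on an aromatic carbon. Among the compounds with values here, this is a small change, removing a single carbon from the core, and nothing among the measured compounds points to a gain in potency from it. The expected step that the limit leaves unreadable from compound 1 to compound 3 is therefore none beyond the scatter, with compound 3 most likely stopping at the same limit as compound 1. The estimate for compound 3 in this assay is 150000 nM, within a range from 40000 nM to 600000 nM.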

Compound 3, half-maximal inhibitory concentration: > 100000 nM
Compound 3: only a limit was reported; the forecaster's own chance of this, stated with the estimate: 85%; the middle value is on the limit's open side.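

Compound 3 gives > 100000 nM in this assay, which is a limit of the assay and not a number. No step from compound 1 to compound 3 can be read, because the values stop at one shared limit: the limit of > 100000 nM in this assay, at which 3 of the 3 values shown sit.

From the compounds shown here alone, whether hydrogen in place of methyl on an aromatic carbon changes potency at all remains open.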